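The source may hold more compounds than are shown below. What is called first, only, known or untested is meant among the compounds shown, and "the series" means these compounds.

In a functional assay on the whole organism (strain albino) with Mus musculus as the target, at a dose of 100 mg/kg by the intraperitoneal route (on this read-out higher numbers stand for more inhibition at the one dose given (going by the name of the read-out) and lower numbers for less inhibition), compound 2 `CCc1nc2ccccc2c(=O)n1NC(=O)Nc1ccc(Br)cc1` gives 54%, level with compound 1 `CCc1nc2ccccc2c(=O)n1NC(=O)Nc1ccccc1`, which in the same test gives 54%. For the measured compounds named here, the one measured step, no change at the digits printed from compound 1 to compound 2 (within the scatter), thus shows bromo entering in place of hydrogen at that place without moving the read-out. Compound 3 `CCc1nc2ccccc2c(=O)n1NC(=O)Nc1ccc(F)cc1` differs from compound 2 by fluoro in place of bromo on an aromatic carbon. Going by the values given here, with the only related step flat, a swap of one halogen for another at the same place is expected to give no change at the digits printed from compound 2 to compound 3 (within the scatter), nothing beyond the scatter. Compound 3 is therefore estimated at 54%, with a range from 40% to 66%.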

Compound 3, a percentage reported as inhibition, in the whole organism at one dose (the size of the read-out at that dose, not a potency): 51%
For compound 3 the middle estimate is 3 percentage points above the measured one; low and high end bracket the measured number.
By their numbers in this assay, from the lowest: compounds 3, 1 and 2 (each within the scatter of the next).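

In this assay the read-out shows a number 3 percentage points lower from compound 2 to compound 3 (within the scatter) for fluoro in place of bromo and a number 3 percentage points lower from compound 1 to compound 3 (within the scatter) for fluoro in place of hydrogen. Hydrogen, bromo and fluoro thus all lie within the scatter of one another at this position, para to a large group, so a second halogen adds no separation here. No measurement offered here explains this flatness. As far as these compounds go, what a methoxy group, an amine or a carboxylic acid would do at this place remains open, as does whether a longer chain in place of the ethyl group on the shared core would move the read-out.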